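Thiophene-fused core: from pyridin-3-yl to 2-methylpyridin-4-yl

The compounds below may be only part of what the source reports. "The series", "measured", "known", "first", "only" and "open" are said of these compounds alone.

Compounds measured so far in an assay on isolated protein for inhibition of Rho-associated protein kinase 1 (Homo sapiens), read by radiometric assay and 33P incorporation, with a stated time of 40 min, in the presence of a further agent that is not named here; on this read-out higher numbers stand for weaker inhibition and lower numbers for stronger inhibition:
compound 1, `COc1cccc(CN2CCc3cc(-c4ccc5[nH]ncc5c4)ccc3C2=O)c1`, gives 2060 nM
compound 2, `COc1cccc(Cn2cnc3sc(-c4cccnc4)cc3c2=O)c1`, gives > 10000 nM

The value for compound 2 in this assay is a limit of the assay and not a number. For the measured compounds named here, on the two values shown, compound 2 therefore sits at the weak end, at the limit of > 10000 nM in this assay, at which 1 of the 2 values shown sits, while compound 1 is the only compound of the pair with a numerical result. Going by the values given here, compound 1 and compound 2 differ in several places at once, so no single step between them can be followed.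

Compound 3, `COc1cccc(Cn2cnc3sc(-c4ccnc(C)c4)cc3c2=O)c1`, is not yet measured. It differs from compound 2 in one place: 2-methylpyridin-4-yl in place of pyridin-3-yl on an aromatic carbon. Among the compounds with values here, no measured step between compounds that differ in one place exists here, so the expectation for this change rests on the structural change alone and is uncertain. Compound 3 is expected to return a number rather than a limit, with the step of an at least 3.3-fold lower number from compound 2 to compound 3 (0.52 log units; beyond the scatter) expected in the direction of stronger inhibition, beyond the scatter. The estimate for compound 3 is 3000 nM, with a range from 600 nM to 15000 nM.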

Compound 3, half-maximal inhibitory concentration: 2520 nM
For compound 3 the middle estimate is 1.2-fold (0.08 log units) above the measured one, within the range that was stated.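

In this assay, placing 2-methylpyridin-4-yl instead of pyridin-3-yl on the aromatic carbon next to the ring sulfur gives an at least 3.9-fold lower number from compound 2 to compound 3 (0.59 log units; beyond the scatter). For the compounds shown here, this is the first step at this position that can be followed, and it shows that a change in this one group is enough to bring the shared core from a limit of the assay to a numerical result. The true size of the step cannot be read, for compound 2 stands at a limit and not at a number: the limit of > 10000 nM in this assay, at which 1 of the 3 values shown sits.

The change is a single swap that alters two things at once, the added methyl and the point at which the pyridine ring is attached, and the compounds shown cannot separate them: that would take pyridin-4-yl or 2-methylpyridin-3-yl on the same carbon. Also open, from the compounds shown here alone, is how far this position tolerates groups of another kind, such as an aliphatic amine, a carboxylic acid or a longer chain in place of the pyridine ring.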